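Pyridine nitrogen position and Vero cell toxicity

The compounds below may be only part of what the source reports. "The series", "measured", "known", "first", "only" and "open" are said of these compounds alone.

Measured compounds:
compound 1 `CC(C)=CCOc1ccc(C(=O)/C=C/c2ccncc2)c(O)c1`: 40000 nM
compound 2 `CC(C)=CCOc1ccc(C(=O)/C=C/c2cccnc2)c(O)c1`: 210000 nM
compound 3 `C#CCOc1ccc(C(=O)/C=C/c2ccncc2)c(OC)c1`: 20000 nM

These three compounds were tested in an ADME assay on Vero cells (Chlorocebus sabaeus) for cytotoxicity, read by resazurin assay, with a stated time of 72 h; on this read-out higher numbers stand for lower toxicity in this test and lower numbers for higher toxicity in this test. Compound 3 gives the lowest number of the three in this assay, though its gap to compound 1 sits within the usual scatter. Compound 1 and compound 2 share one core and differ by pyridin-3-yl in place of pyridin-4-yl on a double-bonded chain carbon bound to a double-bonded chain carbon, a change that brought a 5.3-fold higher number from compound 1 to compound 2 (0.72 log units; beyond the scatter). Compound 4 `C#CCOc1ccc(C(=O)/C=C/c2cccnc2)c(OC)c1` is not yet measured; it differs from compound 3 by pyridin-3-yl in place of pyridin-4-yl on a double-bonded chain carbon bound to a double-bonded chain carbon, the same change at the same place. How the core of compound 3 differs from the core of compound 1 is not broken down here. Among the compounds with values here, because compound 1 to compound 2 showed a 5.3-fold higher number from compound 1 to compound 2 (0.72 log units; beyond the scatter), the step from compound 3 to compound 4 is expected to be a 3.5-fold higher number from compound 3 to compound 4 (0.54 log units; beyond the scatter), though only one earlier example supports this. Compound 4 is estimated at 70000 nM, between 25000 nM and 250000 nM.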

Compound 4, half-maximal cytotoxic concentration: 15000 nM
Beside the measured number, compound 4's estimate is 4.7-fold (0.67 log units) above it, and the stated range ends above it.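

With pyridin-3-yl in place of pyridin-4-yl on the core of compound 3, this assay shows a 1.3-fold lower number from compound 3 to compound 4 (0.12 log units; within the scatter), so the clear rise seen on the core of compound 1 did not carry over. The two results are further apart than repeated measurements would be expected to place them: the same change on two cores in this assay, a 5.3-fold higher number (0.72 log units; beyond the scatter) from compound 1 to compound 2 and a 1.3-fold lower number (0.12 log units; within the scatter) from compound 3 to compound 4, 7.0-fold (0.85 log units) apart, beyond the scatter of two such steps. Within the data shown here, this shows that the same change need not give the same result on both cores, but with only two pairs it does not show which feature of the cores matters or how the change would behave on a third core.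

From the compounds shown here alone, it remains open which difference between the two cores matters. Going by these compounds, it is also open how a pyridin-2-yl group or a plain phenyl ring would behave at this place on either core.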